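Methoxy added to the hydroxyphenyl ring of compound 2

The source may report more compounds than this note shows. Statements on the series, on what has been measured and on what is new or still open speak of the compounds shown alone.

Of the compounds shown here, two carry numbers so far. Compound 1 `C/C(=N\NC(=O)CC#N)c1ccc(S(=O)(=O)N2CCCCC2)cc1` is the open-chain hydrazone; in a functional assay on MCF7 cells (Homo sapiens) for cytotoxicity, read by sulforhodamine B assay, with a stated time of 48 h (a higher number here means a weaker inhibitor, a lower number a stronger inhibitor), compound 1 gives 44200 nM. Compound 2 `CCOC(=O)c1c(-c2ccc(O)cc2)c(C#N)c(=O)n(/N=C(\C)c2ccc(S(=O)(=O)N3CCCCC3)cc2)c1N` closes that hydrazone onto a larger core bearing a 4-hydroxyphenyl group; in this assay compound 2 gives 25500 nM. That is the lower of the two numbers, but the gap to compound 1 is within the scatter, so the two cannot be told apart on these data.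

Compound 3 `CCOC(=O)c1c(-c2ccc(O)c(OC)c2)c(C#N)c(=O)n(/N=C(\C)c2ccc(S(=O)(=O)N3CCCCC3)cc2)c1N` keeps the whole of compound 2 and differs in one place: methoxy in place of hydrogen on an aromatic carbon, ortho to the hydroxy group. Among the compounds with values here, no pair of measured compounds carries this change, so there is nothing to calibrate the step against. A small substituent added this way is expected to move the number little; the expected step from compound 2 to compound 3 in this assay is a 1.2-fold lower number from compound 2 to compound 3 (0.06 log units; within the scatter), in no direction beyond the scatter.

Compound 3 is therefore estimated at 22000 nM in this assay, with a range of 9000 nM to 55000 nM.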

Compound 3, half-maximal inhibitory concentration: 38700 nM
Compound 3: middle estimate off by 1.8-fold (0.25 log units), on the low side, and the stated range covers the measured number.
By their numbers in this assay, from the lowest: compounds 2, 3 and 1 (each within the scatter of the next).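

In this assay the series now has its first pair differing in one place, and the pair shows a 1.5-fold higher number from compound 2 to compound 3 (0.18 log units; within the scatter) for methoxy in place of hydrogen on an aromatic carbon, ortho to a hydroxy group. Within the data shown here, compound 2 and compound 3 therefore cannot be told apart on these data, so going from 4-hydroxyphenyl to 4-hydroxy-3-methoxyphenyl gives this position a first reading in which a group of this size, with one added hydrogen-bond acceptor and no net charge, leaves the number within the scatter; that reading rests on a single pair and on one substituent. The compounds shown offer no measurement that bears on the reason for this result.

Going by these compounds, what a differently built group on the same aromatic carbon would do stays open: an amine, a carboxylic acid or a longer chain such as ethoxy could show whether this position responds at all beyond the scatter. On these data alone, it is equally open whether the methoxy step would read the same without the hydroxy group on the ring, since both compounds in the pair carry it.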